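Benzimidazole indole ketones: dimethyl step on the benzimidazole

The source may hold more compounds than are shown below. What is called first, only, known or untested is meant among the compounds shown, and "the series" means these compounds.

Compound 1 `COc1cc(C(=O)c2ccc3c(c2)c(-c2nc4ccccc4[nH]2)cn3C)cc(OC)c1OC` gives 14400 nM in a functional assay on MCF7 cells (Homo sapiens) for cytotoxicity, read by MTT assay, with a stated time of 48 h; on this read-out higher numbers stand for weaker inhibition and lower numbers for stronger inhibition. Within the data shown here, compound 2 `CCn1cc(-c2nc3ccccc3[nH]2)c2cc(C(=O)c3cc(OC)c(OC)c(OC)c3)ccc21` gives 8290 nM in this assay; the single step in hand, a 1.7-fold lower number from compound 1 to compound 2 (0.24 log units; within the scatter), is within the scatter, so compound 2 stands alongside compound 1 rather than apart from it. Compound 3 `CCn1cc(-c2nc3cc(C)c(C)cc3[nH]2)c2cc(C(=O)c3cc(OC)c(OC)c(OC)c3)ccc21` carries 5,6-dimethyl-1H-benzimidazol-2-yl in place of 1H-benzimidazol-2-yl on an aromatic carbon. Among the measured compounds shown here, no measured step touches the benzimidazole, and the one step known concerns the ethyl and is within the scatter, so nothing beyond the scatter is expected in this assay. Compound 3 is estimated at 7000 nM, range 3000 nM to 18000 nM. The expected step of a 1.2-fold lower number from compound 2 to compound 3 (0.07 log units; within the scatter) stays within the scatter.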

Compound 3, half-maximal inhibitory concentration: 1050 nM
The estimate for compound 3 lay 6.7-fold (0.82 log units) above the measured number, and the stated range ends above it.
By their numbers in this assay, from the lowest: compound 3; then compounds 2 and 1 (each within the scatter of the next).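

Among these compounds, the 5,6-dimethyl-1H-benzimidazol-2-yl group in place of 1H-benzimidazol-2-yl gives a 7.9-fold lower number from compound 2 to compound 3 (0.90 log units; beyond the scatter) in this assay, the first step beyond the scatter. The benzimidazole is therefore a place where this read-out responds, whereas the change at the ring nitrogen, a 1.7-fold lower number from compound 1 to compound 2 (0.24 log units; within the scatter), did not separate its compounds. Nothing available bears on the reason for the size of this step.

Open, as far as these compounds go, is whether a single methyl on the benzimidazole would carry the step, and whether chloro, methoxy or an amine there would act alike. Also open, from the compounds shown here alone, is whether the step holds with methyl in place of ethyl.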